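Shortening the Side Chain of a Biphenyl Carbamate

The source may report more compounds than this note shows. Statements on the series, on what has been measured and on what is new or still open speak of the compounds shown alone.

Compound 1 `O=C(NCCCCc1ccccc1)Oc1cccc(-c2ccccc2)c1` and compound 2 `O=C(NCc1cccc2ccccc12)Oc1cccc(-c2ccccc2)c1` share one core. In a physicochemical assay for pharmacokinetics, read by HPLC, at pH 9.0 (a higher number here means that the compound lasts longer, a lower number that the compound disappears faster), compound 1 gives 0.713 h, and compound 2 gives 0.645 h; these two numbers lie within the scatter of each other, so neither stands apart. Compound 3 `CCCCNC(=O)Oc1cccc(-c2ccccc2)c1` has not yet been measured. It differs from compound 1 by hydrogen in place of phenyl on a saturated chain carbon, four bonds along the chain from an amide-type nitrogen. Among the measured compounds shown here, no measured pair shows this change, so its effect in this assay is open; the step from compound 1 to compound 3 is expected to be small, a 1.0-fold lower number from compound 1 to compound 3 (0.01 log units; within the scatter), with no clear direction beyond the scatter. Compound 3 is therefore expected to give 0.7 h, between 0.4 h and 1.3 h.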

Compound 3, half-life: 0.715 h
Estimate against measurement, compound 3: 1.0-fold (0.01 log units) below; low and high end bracket the measured number.
By their numbers in this assay, from the lowest: compounds 2, 1 and 3 (each within the scatter of the next).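

Hydrogen in place of phenyl on a saturated chain carbon, four bonds along the chain from an amide-type nitrogen, gives a 1.0-fold higher number from compound 1 to compound 3 (0.00 log units; within the scatter) in this assay. Among the compounds shown here, this is the first step read at this position, and it shows that the phenyl can leave without moving the half-life beyond the scatter. No evidence at hand bears on this result.

Going by these compounds, whether an amine or a carboxylic acid in place of the phenyl would move the half-life beyond the scatter remains open. So does the effect of a longer chain.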